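Adding a Second Chloro to an Inactive Series

This account rests on a few compounds, and the source may have more. Where it says the series, first, only, none or still open, it means among the compounds named here.

Three compounds share one core and were tested in a functional assay on K562 cells (Homo sapiens) for antiproliferative activity, read by MTT assay, with a stated time of 24 h; on this read-out higher numbers stand for weaker inhibition and lower numbers for stronger inhibition. Compound 1 `COc1ccc(C(=O)/C=C/c2cccc(F)c2)c2c1C=CC(C)(C)O2` gives only a limit of the assay, > 10000 nM. Compound 2 `COc1ccc(C(=O)/C=C/c2ccsc2)c2c1C=CC(C)(C)O2` likewise gives only a limit, > 10000 nM. Compound 3 `COc1ccc(C(=O)/C=C/c2cccc(Cl)c2)c2c1C=CC(C)(C)O2` also gives only a limit, > 10000 nM. Because all three sit at the limit of > 10000 nM in this assay, at which 3 of the 3 values shown sit, the steps a step that the two limits leave unreadable from compound 1 to compound 2, a step that the two limits leave unreadable from compound 1 to compound 3 and a step that the two limits leave unreadable from compound 2 to compound 3 cannot be sized. Compound 4 `COc1ccc(C(=O)/C=C/c2ccc(Cl)c(Cl)c2)c2c1C=CC(C)(C)O2` differs from compound 3 by chloro in place of hydrogen on an aromatic carbon. Going by the values given here, none of the measured steps has a readable size, so they offer no direction for this change, and a step beyond the scatter is not predicted. The expected step is a step that the limit leaves unreadable from compound 3 to compound 4. Compound 4 is expected to give about 12000 nM, within a range from 3000 nM to 50000 nM, most likely once more only a limit.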

Compound 4, half-maximal inhibitory concentration: 9030 nM
Estimate against measurement, compound 4: 1.3-fold (0.12 log units) above; the range from low to high includes it.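

Going by these compounds alone, compound 4 is the first compound here to give a number rather than a limit in this assay, so adding chloro ortho to a chloro group and para to a large group can at last be given a floor: there is an at least 1.1-fold lower number from compound 3 to compound 4 (0.04 log units; that floor lies within the scatter). The other two comparisons show an at least 1.1-fold lower number from compound 2 to compound 4 (0.04 log units; that floor lies within the scatter) and an at least 1.1-fold lower number from compound 1 to compound 4 (0.04 log units; that floor lies within the scatter). With each floor within the scatter, no real gain is shown, and the steps among compounds 1, 2 and 3 still cannot be read: the limit of > 10000 nM in this assay, at which 3 of the 4 values shown sit.

Still open, from the compounds shown here alone, is whether a single chloro at this place, without the 3-chloro, would give a measurable number. Also open, going by these compounds, is whether an amine or a carboxylic acid there would give a clearly lower one.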